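Two Stereo Changes from Compound 1 to Compound 4

The source may hold more compounds than are shown below. What is called first, only, known or untested is meant among the compounds shown, and "the series" means these compounds.

- compound 1 `Nc1ncnc2c1ncn2/C=C1\C[C@@H]1[C@H](O)CO` gives > 300000 nM (a limit)
- compound 2 `Nc1nc2c(ncn2/C=C2/CC2(CO)CO)c(=O)[nH]1` gives > 100000 nM (a limit)
- compound 3 `Nc1nc2c(ncn2/C=C2/C[C@H]2[C@@H](O)CO)c(=O)[nH]1` gives 299000 nM (a number)

All three compounds were tested in an ADME assay on HFF cells (Homo sapiens) for cytotoxicity, read by neutral red uptake (on this read-out lower numbers stand for higher toxicity in this test and higher numbers for lower toxicity in this test), and sit high on that scale. Compound 1 gives > 300000 nM as a limit, not a number, and this is the highest limit among the values shown. Compound 2 likewise gives a limit (> 100000 nM). Only compound 3 has an actual number (299000 nM).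

Compound 4 `Nc1ncnc2c1ncn2/C=C1/C[C@@H]1[C@@H](O)CO` keeps the atoms and bonds of compound 1 and differs only in configuration as drawn: the two compounds have the same atoms and bonds and differ only in configuration as drawn: 2 of 3 stereo elements differ; a stereocentre at a saturated chain carbon is drawn S in compound 1 and R in compound 4; a double bond is drawn E in compound 1 and Z in compound 4.

Among the compounds with values here, no two measured compounds differ in one place alone, so the data offer no step to compare with. In this assay no change beyond the usual scatter is expected, in either direction. This expectation rests on compound 3, whose number (299000 nM) also lies high. The expected step of a number no higher from compound 1 to compound 4 (the limit leaves the size open) is therefore estimated to be small. For compound 4 the estimated value is 300000 nM, with an expected range from 120000 nM to 600000 nM.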

Compound 4, half-maximal cytotoxic concentration: > 300000 nM
Compound 4: a limit, no number; the forecaster's own chance of this, stated with the estimate: 65%; the middle value lies on the limit itself.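

In this assay compound 4 gives > 300000 nM, a limit and not a number. Compound 1 also gives a limit, > 300000 nM, so the step between these two compounds cannot be read. The compounds shown leave open whether either stereo change, alone or together, alters this read-out.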